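Swapping a Nitro Group for a Fluorophenoxy Ether

The compounds below may be only part of what the source reports. "The series", "measured", "known", "first", "only" and "open" are said of these compounds alone.

Compound 1 `CN1Cc2ccc(OCc3ccc([N+](=O)[O-])cc3)cc2[C@@H](O)C1` and compound 2 `CN1Cc2ccc(OCCc3ccccc3)cc2[C@@H](O)C1` share one core and differ in the ether hanging from it. In an ADME assay on Vero cells (Chlorocebus sabaeus) for cytotoxicity, read by sulforhodamine B assay, with a stated time of 72 h (a lower number here means a stronger inhibitor, a higher number a weaker inhibitor), compound 1 gives > 50000 nM, which is a limit of the assay rather than a number. In this assay compound 2 likewise gives > 50000 nM, again a limit. Both therefore sit at the limit of > 50000 nM in this assay, at which 2 of the 2 values shown sit, so compound 1 stands where compound 2 stands. Compound 3 `CN1Cc2ccc(OCc3ccc(Oc4ccc(F)cc4)cc3)cc2[C@@H](O)C1` differs from compound 1 by 4-fluorophenoxy in place of nitro on an aromatic carbon. Among the measured compounds shown here, no measured step guides this change, and no shift beyond the scatter is expected, so compound 3 is estimated at 60000 nM, within 20000 nM to 200000 nM. The step that the limit leaves unreadable from compound 1 to compound 3 is expected to be essentially flat.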

Compound 3, half-maximal inhibitory concentration: 5600 nM
Compound 3: middle estimate off by 11-fold (1.03 log units), on the high side; the whole stated range lies above it.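

At this place, on an aromatic carbon para to a large group, the choice of substituent does change the reading in this assay: 4-fluorophenoxy in place of nitro brings an at least 8.9-fold lower number from compound 1 to compound 3 (0.95 log units; beyond the scatter). That step is only a minimum, because compound 1 sits at a limit: the limit of > 50000 nM in this assay, at which 2 of the 3 values shown sit.

The compounds shown leave open whether plain phenoxy, without its fluorine, would bring the same step. They also leave open how an amine or a carboxylic acid at this place would read.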